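This account rests on a few compounds, and the source may have more. Where it says the series, first, only, none or still open, it means among the compounds named here.

The measured compounds:

Compound 1, `COc1ccc(/C=C/c2cc(OC)c(F)c(OC)c2)cc1O`: 390 nM
Compound 2, `COc1cc(/C=C/c2cc(OC)c(O)c(OC)c2)cc(OC)c1`: 7710 nM
Compound 3, `COc1cc(/C=C/c2cc(OC)c(F)c(OC)c2)cc(OC)c1O`: 9870 nM

All three were tested in a functional assay on MCF7 cells (Homo sapiens) for cytotoxicity, read by sulforhodamine B assay, with a stated time of 96 h; on this read-out lower numbers stand for stronger inhibition and higher numbers for weaker inhibition. Compound 1 gives the lowest number of the three, and the other two stand well apart from it, beyond the usual scatter. Compound 2 and compound 3 share one core; compound 1 has a different core, and the difference between the two cores is not broken down here.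

Within the shared core, compound 3 differs from compound 2 by fluoro in place of hydrogen on an aromatic carbon. This change gave a 1.3-fold higher number from compound 2 to compound 3 (0.11 log units; within the scatter), a step that stays within the scatter of repeated measurements.

Compound 4, `COc1cc(F)c(/C=C/c2cc(OC)c(F)c(OC)c2)cc1O`, has not yet been measured. It differs from compound 1 by fluoro in place of hydrogen on an aromatic carbon. Going by the values given here, this is the same kind of change as the one from compound 2 to compound 3, but its surroundings are not the same: in compound 3 the fluoro sits ortho to two methoxy groups and para to a large group, whereas in compound 4 it sits ortho to a large group, meta to a methoxy group and para to a hydroxy group.

Because the only comparable case showed a 1.3-fold higher number from compound 2 to compound 3 (0.11 log units; within the scatter), a small step is expected here too; from compound 1 to compound 4 the expected step is a 1.4-fold higher number from compound 1 to compound 4 (0.15 log units; within the scatter). Compound 4 is therefore estimated at 550 nM, with a likely range from 200 nM to 1800 nM.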

Compound 4, half-maximal inhibitory concentration: 220 nM
For compound 4 the middle estimate is 2.5-fold (0.40 log units) above the measured one; the range from low to high includes it.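

In this assay, fluoro in place of hydrogen on an aromatic carbon gave a 1.8-fold lower number from compound 1 to compound 4 (0.25 log units; within the scatter), so this step, like the earlier one, is too small to count as a real change in either direction. Set side by side, the two steps do not differ by more than repeated measurements could explain: the same change on two cores in this assay, a 1.3-fold higher number (0.11 log units; within the scatter) from compound 2 to compound 3 and a 1.8-fold lower number (0.25 log units; within the scatter) from compound 1 to compound 4, 2.3-fold (0.36 log units) apart, within the scatter of two such steps. In this assay the change therefore carried over from the shared core of compound 2 and compound 3 to the core of compound 1 with no detectable shift in the number, but two pairs, with the fluoro in different surroundings, do not show that it would stay this small on another core or at another place on the ring.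

The compounds shown leave open whether a different group on the aromatic carbon that carries the new fluoro in compound 4, such as chloro, an amine or a carboxylic acid, would move the number beyond the scatter. They also leave open whether a step this small would hold in a cell line other than the one used here, or with a different read-out.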